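The source may report more compounds than this note shows. Statements on the series, on what has been measured and on what is new or still open speak of the compounds shown alone.

Compound 1 `ClCc1ccc(Cn2cnc3c(Cl)ncnc32)cc1`: 3160 nM
Compound 2 `ClCc1cccc(Cn2cnc3c(Cl)nc(Cl)nc32)c1`: 2290 nM
Compound 3 `Nc1nc(Cl)c2ncn(Cc3ccccc3CCl)c2n1`: 6310 nM

All three were tested in a functional assay on IGROV-1 cells (Homo sapiens) for cytotoxicity, read by sulforhodamine B assay, with a stated time of 48 h; on this read-out lower numbers stand for stronger inhibition of growth and higher numbers for weaker inhibition of growth. Compound 1 stands second highest of the three numbers; compound 2 lies nearest, within the scatter of compound 1, and compound 3 lies furthest, also within the scatter. Compound 4 `ClCc1ccc(Cn2cnc3c(Cl)nc(Cl)nc32)cc1` has not yet been measured in this assay. It differs from compound 1 in one place: chloro in place of hydrogen on an aromatic carbon. Within the data shown here, no step between measured compounds is available to guide the expectation, so the change is expected to shift the number only slightly, if at all, beyond the scatter, more likely downward than upward. Compound 4 is therefore estimated to give 2500 nM in this assay, with a range from 1000 nM to 6300 nM. That estimate means an expected step of a 1.3-fold lower number from compound 1 to compound 4 (0.10 log units; within the scatter).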

Compound 4, concentration for 50% growth inhibition: 15100 nM
Compound 4: middle estimate off by 6.0-fold (0.78 log units), on the low side; the whole stated range lies below it.
By their numbers in this assay, from the lowest: compounds 2, 1 and 3 (each within the scatter of the next, the first and the last beyond it); then compound 4.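

In this assay, the step of a 4.8-fold higher number from compound 1 to compound 4 (0.68 log units; beyond the scatter) shows that this ring carbon between two ring nitrogen atoms is not indifferent to substitution: chloro in place of hydrogen, a change of a single heavy atom, weakens growth inhibition beyond the scatter. No measurement shown here accounts for this loss.

Among these compounds, only one such swap on an otherwise unchanged structure is available, so it remains open whether the loss is specific to chloro. A fluoro, methyl or methoxy group at this carbon could behave differently.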